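Fluoro in place of nitro on the aryl ring

This account rests on a few compounds, and the source may have more. Where it says the series, first, only, none or still open, it means among the compounds named here.

The series keeps one core, seen in compound 1 `COc1ccc(-n2ncnc2-c2cc(OC)c(OC)c(OC)c2)cc1`, and changes the aryl group on an aromatic nitrogen. In a functional assay on Jurkat cells (Homo sapiens) for antiproliferative activity, read by MTT assay, with a stated time of 72 h (a lower number here means a stronger inhibitor, a higher number a weaker inhibitor), compound 1 gives 93 nM. Compound 2 `COc1cc(-c2ncnn2-c2ccc(Cl)cc2Cl)cc(OC)c1OC` carries 2,4-dichlorophenyl in place of 4-methoxyphenyl on an aromatic nitrogen, and the step of an at least 100-fold higher number from compound 1 to compound 2 (2.03 log units; beyond the scatter) is a large loss. In this assay compound 2 gives only a limit, > 10000 nM. Compound 3 `COc1cc(-c2ncnn2-c2cccc([N+](=O)[O-])c2)cc(OC)c1OC` also stands at a limit in this assay, > 10000 nM, so no number is known for it, only the ceiling at which (the limit of > 10000 nM in this assay, at which 2 of the 3 values shown sit).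

Compound 4 `COc1cc(-c2ncnn2-c2cccc(F)c2)cc(OC)c1OC` differs from compound 3 by fluoro in place of nitro on an aromatic carbon, the change sitting meta to a large group. Within the data shown here, no measured step isolates a change at this place; the one measured step, from compound 1 to compound 2, shows that a swap of the aryl group can move the value far beyond the scatter. Because compound 3 gives only the limit > 10000 nM, the size of any shift from it cannot be set against a number, and the estimate for compound 4 is therefore broad. Compound 4 is expected to remain weak in this assay, at about 6000 nM, within 600 nM to 40000 nM, which would mean an expected step of an at least 1.6-fold lower number from compound 3 to compound 4 (0.22 log units; that floor lies within the scatter).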

Compound 4, half-maximal inhibitory concentration: > 10000 nM
Compound 4: a limit, no number (the forecaster's own chance of this, stated with the estimate: 45%); middle value at least 1.6-fold (0.22 log units) from the limit.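

In this assay compound 4 gives only a limit, > 10000 nM, so fluoro on the aromatic carbon meta to a large group yields no number, just as nitro did at that place. On the aromatic nitrogen, 3-fluorophenyl in place of 4-methoxyphenyl gives an at least 100-fold higher number from compound 1 to compound 4 (2.03 log units; beyond the scatter), a large loss, which makes 3-fluorophenyl the third aryl group shown, after those of compound 2 and compound 3, without a measured value; among the compounds shown, only compound 1, with 4-methoxyphenyl, has one. The steps to compound 4 from compound 2 and from compound 3 cannot be read, and the ceiling now holds most of the series: the limit of > 10000 nM in this assay, at which 3 of the 4 values shown sit.

As far as these compounds go, how far compound 2, compound 3 and compound 4 lie past the limit, and any order among them, stays unknown. An amine, a hydroxyl or an ethoxy group on the aryl ring could show whether any aryl group other than 4-methoxyphenyl gives a number in this assay.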